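Aryl ether side chain: diol replaced by tetramethylpiperidinyl

The compounds below may be only part of what the source reports. "The series", "measured", "known", "first", "only" and "open" are said of these compounds alone.

Compound 1 `O=C(N[C@@H]1CCNC1)c1cc(-c2ccc(NS(=O)(=O)c3cccc(Cl)c3Cl)cc2)nc2[nH]ncc12`, compound 2 `CC(C)N1CC[C@H](NC(=O)c2cc(-c3ccc(NS(=O)(=O)c4cccc(Cl)c4Cl)cc3)nc3[nH]ncc23)C1` and compound 3 `Cc1n[nH]c2nc(-c3ccc(NS(=O)(=O)c4cc(Cl)ccc4F)cc3)nc(OCC(CO)CO)c12` share a core carrying an aryl sulfonamide and differ at the solvent-facing side chain. In an assay for inhibition of serine/threonine-protein kinase Sgk1 (Homo sapiens), with stated times of 30 min and 60 min, in the presence of a further agent that is not named here (a higher number here means a weaker inhibitor, a lower number a stronger inhibitor), compound 1 reaches the limit < 1 nM, which is a limit and not a number (the limit of < 1 nM in this assay, at which 1 of the 3 values shown sits). In this assay compound 2 gives 4 nM, and compound 3 gives 1 nM. Among the two numbers, compound 3 stands lowest, with compound 2 as the nearest neighbour. Going by the values given here, the one step within a single position, an at least 4.0-fold higher number from compound 1 to compound 2 (0.60 log units; beyond the scatter), shows that enlarging the basic amine side chain weakens binding by at least a modest amount.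

Compound 4 `Cc1n[nH]c2nc(-c3ccc(NS(=O)(=O)c4cc(Cl)ccc4F)cc3)nc(OC3CC(C)(C)NC(C)(C)C3)c12` differs from compound 3 by 2,2,6,6-tetramethylpiperidin-4-yl in place of 3-hydroxy-2-(hydroxymethyl)propyl on an oxygen on an aromatic ring. Among the compounds with values here, no measured step touches the aryl ether position, so the step from compound 1 to compound 2 is only a loose guide; the change is larger and more branched, and a small loss is expected rather than none. Compound 4 is therefore estimated at 3 nM, within 1 nM to 10 nM, an expected step of a 3.0-fold higher number from compound 3 to compound 4 (0.48 log units; beyond the scatter).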

Compound 4, half-maximal inhibitory concentration: 3 nM
Compound 4: middle estimate and measured number agree at the digits printed; measured number inside the range.
By their numbers in this assay, from the lowest: compound 3; then compounds 4 and 2 (each within the scatter of the next).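

In this assay, replacing 3-hydroxy-2-(hydroxymethyl)propyl with 2,2,6,6-tetramethylpiperidin-4-yl on the oxygen carries a modest cost, with a 3.0-fold higher number from compound 3 to compound 4 (0.48 log units; beyond the scatter). Going by these compounds alone, this is the first reading at the aryl ether position, and it shows that the diol chain is not required, since compound 4 still gives 3 nM with a six-membered non-aromatic ring in its place. Compound 1 alone sits at a limit, which is not a number, and this step does not touch it: the limit of < 1 nM in this assay, at which 1 of the 4 values shown sits.

As far as these compounds go, whether the loss follows from removing the hydroxyl groups, adding the ring or adding the methyl groups stays open; a piperidin-4-yl without methyl groups, a plain alkyl chain or a carboxylic acid on the same oxygen would separate these. Also open, from the compounds shown here alone, is whether the change reads the same with another aryl group on the sulfonamide.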